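A few compounds are considered here, and "the series" means these few. Any claim that something is new, unique, unknown or untested is made for them only; others in the source may bear on it.

Measured so far in an assay on HEK293 cells for inhibition of sialidase-3 (Homo sapiens), read by fluorescence, with a stated time of 1 h; on this read-out higher numbers stand for weaker inhibition and lower numbers for stronger inhibition:
- compound 1 `CCO[C@@]1(C(=O)O)C=C[C@@H](NC(C)=O)[C@H]([C@H](O)[C@H](O)CO)O1`: > 1000000 nM
- compound 2 `CC(=O)N[C@@H]1C=C[C@@](OC(C)C)(C(=O)O)O[C@H]1[C@H](O)[C@H](O)CO`: > 1000000 nM

Compound 1 gives > 1000000 nM in this assay, which is a limit of the assay and not a number. Compound 2 gives > 1000000 nM in this assay, likewise a limit of the assay. Between them lies a step that the two limits leave unreadable from compound 1 to compound 2, so the exchange of the ethoxy for the isopropoxy group cannot be sized from these data. Compound 2 therefore stands only at a limit, and the other value shown is a limit as well; both sit at the limit of > 1000000 nM in this assay, at which 2 of the 2 values shown sit.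

The next compound, compound 3 `CCCCCCCCS[C@@]1(C(=O)O)C=C[C@@H](NC(C)=O)[C@H]([C@H](O)[C@H](O)CO)O1`, differs from compound 2 by octylsulfanyl in place of isopropoxy on a saturated ring carbon. No measured step bears on an exchange of an alkoxy group for an alkylsulfanyl chain: the only step available, a step that the two limits leave unreadable from compound 1 to compound 2, is unreadable, and nothing shown says whether the long octylsulfanyl chain will move the series off the limit. The step from compound 2 to compound 3 is estimated as an at least 1.2-fold lower number from compound 2 to compound 3 (0.09 log units; that floor lies within the scatter), wide and uncertain. Compound 3 is expected at 800000 nM, with a range from 50000 nM to 5000000 nM.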

Compound 3, half-maximal inhibitory concentration: > 1000000 nM
Compound 3 was reported as a limit (the forecaster's own chance of this, stated with the estimate: 65%); middle value at least 1.2-fold (0.09 log units) away from the limit.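

In this assay compound 3 gives > 1000000 nM, a limit of the assay and not a number. The steps among compound 1, compound 2 and compound 3 therefore cannot be read: the limit of > 1000000 nM in this assay, at which 3 of the 3 values shown sit.

The compounds shown leave open whether any group on this saturated ring carbon brings the read-out off that limit in this assay.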